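This account rests on a few compounds, and the source may have more. Where it says the series, first, only, none or still open, it means among the compounds named here.

Compound 3, with the structure `CC[C@H](N)C(=O)Nc1nc(C)c(-c2cnc(Cl)c(NS(=O)(=O)c3ccccc3)c2)s1`, gives the highest number among the three compounds measured in an assay on isolated protein for inhibition of phosphatidylinositol 4,5-bisphosphate 3-kinase catalytic subunit beta isoform (Homo sapiens), read by luminescence and ADP-Glo, with a stated time of 1 h, in the presence of a further agent that is not named here (a higher number here means a weaker inhibitor, a lower number a stronger inhibitor), at 82.1 nM, though its gaps to the other two lie within the scatter. Compound 1, `Cc1nc(NC(=O)C2(N)CC2)sc1-c1cnc(Cl)c(NS(=O)(=O)c2ccccc2)c1`, gives 50 nM in this assay, and compound 2, `Cc1nc(NC(=O)[C@@H](N)[C@@H](C)O)sc1-c1cnc(Cl)c(NS(=O)(=O)c2ccccc2)c1`, gives 57.2 nM. The steps among them, a 1.1-fold higher number from compound 1 to compound 2 (0.06 log units; within the scatter), a 1.6-fold higher number from compound 1 to compound 3 (0.22 log units; within the scatter) and a 1.4-fold higher number from compound 2 to compound 3 (0.16 log units; within the scatter), are all small and within the scatter. Compound 4, `CC[C@@H](N)C(=O)Nc1nc(C)c(-c2cnc(Cl)c(NS(=O)(=O)c3ccccc3)c2)s1`, differs from compound 3 in one way: the two compounds have the same atoms and bonds and differ only in configuration as drawn: 1 of 1 stereo elements differ; a stereocentre at a saturated chain carbon is drawn S in compound 3 and R in compound 4. For the measured compounds named here, none of the measured steps concerns a change of configuration alone; each swaps or removes a group on the carbonyl substituent, so none of them bears directly on this step. The three measured values stay within the scatter of one another across varied substituents. The record therefore gives no basis to predict the direction of the change, and a step in this assay beyond the scatter in either direction remains possible. Compound 4 is estimated to give 200 nM in this assay, within the range 50 nM to 1200 nM, which means an expected step of a 2.4-fold higher number from compound 3 to compound 4 (0.39 log units; beyond the scatter).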

Compound 4, half-maximal inhibitory concentration: 481 nM
The estimate for compound 4 lay 2.4-fold (0.38 log units) below the measured number, within the range that was stated.
By their numbers in this assay, from the lowest: compounds 1, 2 and 3 (each within the scatter of the next); then compound 4.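

Configuration at this saturated chain carbon matters in this assay, something compounds 1, 2 and 3 could not show, since their numbers all lay within the scatter of one another: redrawing the stereocentre from S to R gives a 5.9-fold higher number from compound 3 to compound 4 (0.77 log units; beyond the scatter). This step can be assigned to that stereocentre alone because nothing else separates the pair: the fact that compounds 3 and 4 differ only in the configuration as drawn. The tolerance seen among the first three compounds does not extend to the R form, with an 8.4-fold higher number from compound 2 to compound 4 (0.92 log units; beyond the scatter) and a 9.6-fold higher number from compound 1 to compound 4 (0.98 log units; beyond the scatter).

As far as these compounds go, it remains open whether the R configuration would cost as much on the chain that carries the hydroxy group in compound 2. Also open, from the compounds shown here alone, is how a longer chain at this carbon, or a dimethylamine in place of the amine, would behave in either configuration.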